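A few compounds are considered here, and "the series" means these few. Any claim that something is new, unique, unknown or untested is made for them only; others in the source may bear on it.

In a functional assay on RAW264.7 cells (Mus musculus) for cytotoxicity, read by MTT assay, with a stated time of 48 h, tested at 100 uM (a lower number here means a weaker effect, a higher number a stronger effect of the compound at the concentration tested), three compounds that share one core have been measured so far. Compound 2 `CS(=O)(=O)c1ccc(Cc2nnc3n2N=C(c2cc(Cl)sc2S(N)(=O)=O)CS3)cc1` gives 35.2%, the lowest of the three numbers. Its nearest neighbour is compound 3 `CS(=O)(=O)c1ccc(Cc2nnc3n2N=C(c2cc(Cl)sc2Cl)CS3)cc1`, which gives 47.3%, and the furthest is compound 1 `CS(=O)(=O)c1ccc(Cc2nnc3n2N=C(c2ccc(-c4ccccc4)cc2)CS3)cc1`, which gives 74.8%. Compound 4 `CS(=O)(=O)c1ccc(Cc2nnc3n2N=C(c2ccc(Cl)cc2Cl)CS3)cc1` has not yet been measured. It differs from compound 2 in one place: 2,4-dichlorophenyl in place of 5-chloro-2-sulfamoylthiophen-3-yl on a carbon with a double bond to nitrogen. Among the compounds with values here, one measured step bears on this change: a number 12.1 percentage points higher from compound 2 to compound 3 (beyond the scatter), a step in which the sulfamoyl was removed from an aromatic carbon. Within the data shown here, compound 4 also loses the sulfamoyl, but it exchanges the whole ring as well, and no measured pair shows that exchange on its own; compound 1 shows only that the shared core can reach a high number. The step is therefore expected to be upward, modest or somewhat larger, a number 16.8 percentage points higher from compound 2 to compound 4 (beyond the scatter). Compound 4 is estimated to give 52%, within a range from 36% to 68%.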

Compound 4, a percentage reported as activity, at one concentration (the size of the read-out at that concentration, not a potency): 31%
For compound 4 the middle estimate is 21 percentage points above the measured one; the whole stated range lies above it.
By their numbers in this assay, from the lowest: compounds 4 and 2 (each within the scatter of the next); then compound 3; then compound 1.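

In this assay, exchanging 5-chloro-2-sulfamoylthiophen-3-yl for 2,4-dichlorophenyl on this carbon with a double bond to nitrogen gives a number 4.2 percentage points lower from compound 2 to compound 4 (within the scatter), so losing the sulfamoyl does not carry a higher number with it when the ring is exchanged as well. Between the two compounds without a sulfamoyl, the ring exchange alone gives a number 16.3 percentage points lower from compound 3 to compound 4 (beyond the scatter), which shows that at this position 2,4-dichlorophenyl and 2,5-dichlorothiophen-3-yl cannot be treated as equivalent. No available measurement accounts for either step.

The compounds shown leave open how a phenyl ring with a single chlorine would behave at this position, and whether a sulfamoyl on a phenyl ring would behave as it does on the thiophene. They also leave open what an amine or a carboxylic acid on that ring would give.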